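Swapping an Aryl Amide for a Pyrimidinyl Amide

The source may hold more compounds than are shown below. What is called first, only, known or untested is meant among the compounds shown, and "the series" means these compounds.

Measured so far:
Compound 1, `Cc1cc(C)cc(NC(=O)COc2cc(C)nc3ccc(F)cc23)c1`: 5.79
Compound 2, `COc1ccc2nc(C)cc(OCC(=O)Nc3cccc(C)c3)c2c1`: 4.83

Both compounds were read in a physicochemical assay for lipophilicity, read by HPLC, in phosphate buffer, measured as chromatographic lipophilicity, at pH 7.4; a higher number here means a more lipophilic compound, a lower number a more polar compound. Compound 1 gives 5.79 in this assay, and compound 2 gives 4.83. Of the two numbers, compound 2 stands lowest, with compound 1 nearly one unit higher, a gap well beyond the usual scatter of the method. Going by the values given here, the two structures differ in more than one place, so no single step between them is counted here; only their two values can be compared.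

The step followed now leads from compound 2 to compound 3, `COc1ccc2nc(C)cc(OCC(=O)Nc3ccncn3)c2c1`, which has not yet been measured in this assay. The change is pyrimidin-4-yl in place of 3-methylphenyl on an amide-type nitrogen. This means an aromatic ring of carbon only, bearing a methyl, gives way to a ring with two nitrogen atoms and two hydrogen-bond acceptors, with the amide-type nitrogen and its carbonyl neighbour unchanged.

Among the compounds with values here, no measured pair shows this change, so the expected size of the step rests on the change itself. A downward step of a number 1.53 log units lower from compound 2 to compound 3 (beyond the scatter) in this assay is expected, clearly beyond the scatter. Compound 3 is estimated at 3.3, with a range from 2.7 to 3.9.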

Compound 3, distribution coefficient: 2.53
Compound 3: middle estimate off by 0.77 log units, on the high side; the measured number lies below the stated range.
By their numbers in this assay, from the lowest: compound 3; then compound 2; then compound 1.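

In this assay, going by these compounds alone, placing pyrimidin-4-yl instead of 3-methylphenyl on the amide-type nitrogen brings a number 2.30 log units lower from compound 2 to compound 3 (beyond the scatter), and this is the first comparison here in which only one place changes. It shows that the group on this nitrogen can, on its own, shift the reading by a large amount while the shared core, the carbonyl and the amide-type nitrogen stay as they were. The swap is still a compound change: a ring of carbon only loses its methyl and gives way to a ring with 2 nitrogen atoms, and the data on hand include no measurement that explains the size of the step.

As far as these compounds go, what stays open is how much of the step belongs to losing the methyl and how much to the ring nitrogen atoms, since both happen in this one change. A plain phenyl or a pyridinyl ring on the same nitrogen would help to separate those two parts, and an amine or a carboxylic acid on the ring would show how far the reading moves with groups of a quite different kind.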